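The compounds below may be only part of what the source reports. "The series", "measured", "known", "first", "only" and "open" are said of these compounds alone.

Working notes on the series. In a functional assay on CHO cells for agonist activity at Alpha-1A adrenergic receptor (Homo sapiens), read by FLIPR and calcium flux (a higher number here means that more compound is needed for the effect, a lower number that less compound is needed), compound 1 `COCc1ccccc1C1CCc2nc[nH]c2C1` gives 76 nM; 48 nM (2 entries); the two entries fall within the scatter of each other (the several entries of compound 1 in this assay, 76 nM; 48 nM (2 entries)). Compound 3 `Clc1ccccc1C1CCc2nc[nH]c2C1` gives 276 nM in this assay. Compound 2 `COc1ccc(C2Cc3nccn3C2)cc1` gives 939 nM in this assay, the highest of the two numbers recorded as single values; its nearest neighbour is compound 3, and that gap lies beyond the scatter.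

Compound 4 `Clc1ccc(C2Cc3nccn3C2)cc1` has not been measured in this assay. It differs from compound 2 by chloro in place of methoxy on an aromatic carbon. Going by the values given here, no measured pair carries this same change, so its size has no direct precedent here. The step is expected to be small, at most around the edge of the scatter, and if anything toward a lower number: a 1.6-fold lower number from compound 2 to compound 4 (0.19 log units; within the scatter). Compound 4 is therefore estimated at 600 nM in this assay, with a range from 200 nM to 2500 nM.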

Compound 4, half-maximal effective concentration in the Alpha-1A adrenergic receptor assay: 3460 nM
Compound 4: middle estimate off by 5.8-fold (0.76 log units), on the low side; the measured number lies above the stated range.
By their numbers in the Alpha-1A adrenergic receptor assay, from the lowest: compound 3; then compound 2; then compound 4.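

Going by these compounds alone, in the Alpha-1A adrenergic receptor assay this position on the six-membered aromatic ring responds to the exchange, and chloro in place of methoxy gives the only one-place step (a 3.7-fold higher number from compound 2 to compound 4 (0.57 log units; beyond the scatter)). Of this pair, methoxy holds the lower number. The same change also raises lipophilicity in a physicochemical assay for lipophilicity, at pH 7.4; on this read-out lower numbers stand for lower lipophilicity and higher numbers for higher lipophilicity: (the measured distribution coefficient of compound 2, 2, and of compound 4, 2.6, a number 0.60 log units higher (beyond the scatter)). In the physicochemical assay compound 2 gives 2 and compound 4 gives 2.6.

A single pair cannot tell whether the rise in the Alpha-1A adrenergic receptor assay follows that lipophilicity or the group itself. On these data alone, how an amine or an ethoxy group would fare on this aromatic carbon stays open, as does whether the step carries over to the core of compound 1.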